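Swapping a benzyloxy group for a methyl-oxadiazole

The source may report more compounds than this note shows. Statements on the series, on what has been measured and on what is new or still open speak of the compounds shown alone.

Cytotoxicity here is followed in an ADME assay on HepG2 cells (Homo sapiens) for cytotoxicity, read by CellTiter-Glo and resazurin assay, with a stated time of 72 h; on this read-out lower numbers stand for an effect already at smaller amounts and higher numbers for an effect only at larger amounts of compound. Compound 1 `CC(C)N(Cc1cccc(OCCCCCC(=O)O)c1)C(=O)c1ccc(-c2ccsc2)cc1` is one of two measured compounds. In this assay compound 1 gives only a limit, > 26000 nM. Compound 2 `CC(C)N(Cc1cccc(OCCCCCC(=O)O)c1)C(=O)c1ccc(-c2cccc(OCc3ccccc3)c2)cc1` shares the same core and acid-bearing chain. In this assay compound 2 likewise gives only a limit, > 26000 nM. For the measured compounds named here, both values thus sit at the limit of > 26000 nM in this assay, at which 2 of the 2 values shown sit, so the two compounds cannot be told apart and no step between them can be read. Compound 3 `Cc1nnc(-c2cccc(-c3ccc(C(=O)N(Cc4cccc(OCCCCCC(=O)O)c4)C(C)C)cc3)c2)o1` is not yet measured; it differs from compound 2 in one place, (5-methyl-1,3,4-oxadiazol-2-yl in place of benzyloxy on an aromatic carbon), that is 5-methyl-1,3,4-oxadiazol-2-yl in place of benzyloxy on an aromatic carbon. Going by the values given here, with no measured step available, the expected step that the limit leaves unreadable from compound 2 to compound 3 is none beyond the scatter, and another limit is the likeliest outcome. Compound 3 is estimated at 40000 nM, within a range from 20000 nM to 100000 nM.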

Compound 3, half-maximal effective concentration: > 26000 nM
Compound 3: no number, only a limit; the forecaster's own chance of this, stated with the estimate: 85%; the middle value is on the limit's open side.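

In this assay compound 3 also gives only a limit, so the steps linking it to compound 1 and compound 2 cannot be read: the limit of > 26000 nM in this assay, at which 3 of the 3 values shown sit.

The compounds shown leave open whether 5-methyl-1,3,4-oxadiazol-2-yl in place of benzyloxy changes the concentration at which any effect on these cells appears.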